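A few compounds are considered here, and "the series" means these few. Any claim that something is new, unique, unknown or untested is made for them only; others in the source may bear on it.

Compound 1 `Cc1nn(-c2ncnc3nc[nH]c23)c2c1C(OCc1ccc(C(C)C)cc1)CC(=O)N2`: 5 nM
Compound 2 `CCC(C(=O)NC1CC(=O)Nc2c1c(C)nn2-c1ncnc2nc[nH]c12)c1ccccc1`: 5 nM
Compound 3 `Cc1nn(-c2ncnc3nc[nH]c23)c2c1C(C(=O)NCc1ccc(F)cc1)CC(=O)N2`: 4 nM

Of the compounds shown here, three have so far been measured in a functional assay on HEK293 cells for agonist activity at G-protein coupled receptor 39 (Homo sapiens), read by scintillation proximity assay and inositol phosphate accumulation, with a stated time of 75 min, in the presence of a further agent that is not named here; on this read-out lower numbers stand for an effect already at smaller amounts and higher numbers for an effect only at larger amounts of compound. Compound 1 gives 5 nM, compound 2 gives 5 nM and compound 3 gives 4 nM. All three numbers lie within the usual scatter of one another: compound 1 stands level with compound 2 at the digits shown, and compound 3 differs from it only within the scatter, so no order among the three can be read from these numbers.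

The next compound, compound 4 `CCCCCCCCOC1CC(=O)Nc2c1c(C)nn2-c1ncnc2nc[nH]c12`, is still to be measured in this assay. It differs from compound 1 in one place: heptyl in place of 4-isopropylphenyl on a saturated chain carbon bound to an oxygen on a saturated carbon. Among the compounds with values here, no measured pair in this set shows a change of this kind, so the size of the step rests on expectation alone. Compound 1 carries a six-membered aromatic ring of carbon only in the part that changes, and compound 4 has no ring there; the measured compounds give no guide to what such a change does. A modest weakening is expected, a step of a 4.0-fold higher number from compound 1 to compound 4 (0.60 log units; beyond the scatter), with a wide range to reflect the lack of precedent. Compound 4 is therefore estimated at 20 nM, with a range from 4 nM to 120 nM.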

Compound 4, half-maximal effective concentration: 8 nM
Estimate against measurement, compound 4: 2.5-fold (0.40 log units) above; the measured number falls inside the stated range.
By their numbers in this assay, from the lowest: compounds 3, 1, 2 and 4 (each within the scatter of the next).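

In this assay, heptyl in place of 4-isopropylphenyl on a saturated chain carbon bound to an oxygen on a saturated carbon gives a 1.6-fold higher number from compound 1 to compound 4 (0.20 log units; within the scatter), a step within the usual scatter, so this pair cannot be told apart by its numbers. For this one pair, then, the six-membered aromatic ring of carbon only can give way to an open chain with no ring, with no step beyond the scatter, and the isopropyl-bearing aromatic group is not required for a low number at this position. No measurement here explains why the two groups read alike, so the result stands as an observation without a stated cause.

From the compounds shown here alone, both groups carry no hydrogen-bond donors or acceptors and no net charge, so it remains open whether an amine or a carboxylic acid at the end of the chain would leave the number where it is, and whether a much shorter chain such as ethyl or a longer one such as dodecyl would do the same. Compounds 2 and 3 differ from compound 1 in more than this one place, so they cannot show how far this single pair's result extends.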